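Phenyl for Cyclohexyl at the Branch Carbon

The source may hold more compounds than are shown below. What is called first, only, known or untested is meant among the compounds shown, and "the series" means these compounds.

Compound 1 `CC1CCN(c2nc(C(F)(F)F)ccc2CNC(=O)C(c2ccc(NS(C)(=O)=O)c(F)c2)C2CCCC2)CC1`: 88.7 nM
Compound 2 `CC1CCN(c2nc(C(F)(F)F)ccc2CNC(=O)C(c2ccc(NS(C)(=O)=O)c(F)c2)C2CCCCC2)CC1`: 31.1 nM

In an assay on CHO cells for antagonist activity at transient receptor potential cation channel subfamily V member 1 (Homo sapiens), read by FLIPR (a higher number here means a weaker inhibitor, a lower number a stronger inhibitor), compound 2 gives 31.1 nM, the lowest of the two numbers, while compound 1 gives 88.7 nM. Compound 3 `CC1CCN(c2nc(C(F)(F)F)ccc2CNC(=O)C(c2ccccc2)c2ccc(NS(C)(=O)=O)c(F)c2)CC1` differs from compound 2 by phenyl in place of cyclohexyl on a saturated chain carbon bound to an aromatic carbon and a carbonyl carbon. Within the data shown here, only one measured step bears on this place: a 2.9-fold lower number from compound 1 to compound 2 (0.46 log units; beyond the scatter), where one saturated ring replaced another. The step to compound 3 instead exchanges a non-aromatic ring for an aromatic one of the same size, so that earlier step offers only weak guidance, and no change beyond the scatter is expected. Compound 3 is therefore estimated at 50 nM, with a range from 15 nM to 160 nM, which means an expected step of a 1.6-fold higher number from compound 2 to compound 3 (0.21 log units; within the scatter).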

Compound 3, inhibition constant: 1.3 nM
Beside the measured number, compound 3's estimate is 38-fold (1.59 log units) above it; the whole stated range lies above it.
By their numbers in this assay, from the lowest: compound 3; then compound 2; then compound 1.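

Among these three compounds, at the saturated chain carbon bound to an aromatic carbon and a carbonyl carbon, the kind of ring counts for more than its size in this assay and the change to an aromatic ring outweighs a 2.9-fold lower number from compound 1 to compound 2 (0.46 log units; beyond the scatter) between the two saturated rings. Phenyl in place of cyclohexyl, with the same count of heavy atoms, gives a 24-fold lower number from compound 2 to compound 3 (1.38 log units; beyond the scatter) and phenyl in place of cyclopentyl gives a 68-fold lower number from compound 1 to compound 3 (1.83 log units; beyond the scatter) at this carbon. Nothing available explains why this ring change has so large an effect.

The compounds shown leave open whether a pyridyl ring could stand in place of the phenyl with a similar result. They also leave open how a fluoro or methoxy group on that phenyl would shift the number.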